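The compounds below may be only part of what the source reports. "The series", "measured", "known", "first", "only" and "open" are said of these compounds alone.

In a functional assay on MCF7 cells (Homo sapiens) for cytotoxicity, read by MTT assay, with a stated time of 72 h (a lower number here means a stronger inhibitor, a higher number a weaker inhibitor), compound 1 `COc1c(OCCCCN2CCN(C)CC2)cc(O)c2c(=O)cc(-c3ccc([N+](=O)[O-])cc3)oc12` gives 4090 nM, compound 2 `O=c1cc(-c2ccccc2)oc2c(OCCCN3CCCC3)c(OCc3ccccc3)cc(O)c12` gives 2230 nM and compound 3 `Cc1ccc(COc2cc(O)c3c(=O)cc(-c4ccccc4)oc3c2OCCCCN2CCN(C)CC2)cc1` gives 2220 nM. On these numbers compound 3 stands alongside compound 2 and compound 1, all three values falling within the scatter of one another, so no ordering among them can be read. Compound 4 `CN1CCN(CCCCOc2c(OCc3nc4ccccc4o3)cc(O)c3c(=O)cc(-c4ccccc4)oc23)CC1` differs from compound 3 in one place: 1,3-benzoxazol-2-yl in place of 4-methylphenyl on a saturated chain carbon bound to an oxygen on an aromatic ring. For the measured compounds named here, no measured pair shows this change, so its effect is unknown. With nothing in the measured compounds pointing either way, the step of a 1.1-fold higher number from compound 3 to compound 4 (0.05 log units; within the scatter) is expected to stay within the scatter. Compound 4 is therefore estimated at 2500 nM in this assay, with a range from 900 nM to 7000 nM.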

Compound 4, half-maximal inhibitory concentration: 4980 nM
Compound 4: the middle estimate sits 2.0-fold (0.30 log units) below what was measured; low and high end bracket the measured number.
By their numbers in this assay, from the lowest: compounds 3, 2, 1 and 4 (each within the scatter of the next, the first and the last beyond it).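

In this assay the group on this saturated chain carbon bound to an oxygen on an aromatic ring is not silent: 1,3-benzoxazol-2-yl in place of 4-methylphenyl gives a 2.2-fold higher number from compound 3 to compound 4 (0.35 log units; beyond the scatter), a modest step and the first one available here. The larger group with two hydrogen-bond acceptors thus goes with a weaker number at this position. Nothing available explains this step. Open, on these data alone, is whether the fused benzene ring or the ring nitrogen and oxygen carry the change, and whether a pyridin-2-yl or 1,3-benzothiazol-2-yl would follow compound 3 or compound 4.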